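Diethylamino for ethoxy on a carbonyl carbon

The source may hold more compounds than are shown below. What is called first, only, known or untested is meant among the compounds shown, and "the series" means these compounds.

- compound 1 `COc1cccc2cc(-c3ccccc3)c(O)nc12`: 10000 nM
- compound 2 `COc1cc(OC)c2cc(-c3ccc(OCc4ccccc4)cc3)c(O)nc2c1`: 10000 nM
- compound 3 `CCOC(=O)Cn1c(=O)c(-c2ccc(OC)cc2)cc2c(OC)cc(OC)cc21`: 10000 nM

In a functional assay on A549 cells (Homo sapiens) for cytotoxicity, read by colorimetric assay and MTT assay (on this read-out lower numbers stand for stronger inhibition and higher numbers for weaker inhibition), compound 3 gives 10000 nM, level with compound 1 and compound 2, so the three compounds cannot be told apart on this measure. Compound 4 `CCN(CC)C(=O)Cn1c(=O)c(-c2ccc(OC)cc2)cc2c(OC)cc(OC)cc21` has the same structure as compound 3 except for one swap, diethylamino in place of ethoxy on a carbonyl carbon. Among the measured compounds shown here, no measured pair differs in just one place, so no earlier step can guide the forecast. The expected change, a 1.3-fold lower number from compound 3 to compound 4 (0.10 log units; within the scatter), is no larger than the usual scatter, with no clear direction. For compound 4 the estimated value is 8000 nM, with an expected range from 3000 nM to 15000 nM.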

Compound 4, half-maximal inhibitory concentration: 10000 nM
For compound 4 the middle estimate is 1.3-fold (0.10 log units) below the measured one; measured number inside the range.
By their numbers in this assay, from the lowest: compounds 1, 2, 3 and 4 (each within the scatter of the next).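

In this assay, among the compounds shown here, the swap shows no change at the digits printed from compound 3 to compound 4 (within the scatter), the first comparison here between compounds that differ in one place. On this read-out, ethoxycarbonyl and diethylcarbamoyl on the (saturated) chain cannot be told apart, so this change alone does not separate the two compounds. Nothing available explains this result.

Still open, on these data alone, is whether a carboxylic acid or a cyclic amide such as morpholine amide in this place would give a different number. A longer chain leading to the carbonyl carbon is equally untested by the compounds shown.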